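Removing Ring Chlorines and Methylating the Chain Amine

A few compounds are considered here, and "the series" means these few. Any claim that something is new, unique, unknown or untested is made for them only; others in the source may bear on it.

Compound 2 `O=S(=O)(NCCCNCc1ccc(Cl)c(Cl)c1)c1cc(C(F)(F)F)cc(C(F)(F)F)c1` gives 2400 nM in a functional assay on MCF7 cells (Homo sapiens) for inhibition, read by MTT assay, with a stated time of 72 h (on this read-out higher numbers stand for weaker inhibition of growth and lower numbers for stronger inhibition of growth), the lowest of the two numbers shown, while compound 1 `O=S(=O)(NCCCNCc1ccccc1Cl)c1cc(C(F)(F)F)cc(C(F)(F)F)c1` gives 8800 nM. For the measured compounds named here, the only measured step, a 3.7-fold lower number from compound 1 to compound 2 (0.56 log units; beyond the scatter), bears on the change to compound 3 `CN(CCCNS(=O)(=O)c1cc(C(F)(F)F)cc(C(F)(F)F)c1)Cc1ccccc1`, which is benzyl(methyl)amino in place of (3,4-dichlorobenzyl)amino on a saturated chain carbon, three bonds along the chain from a sulfonamide nitrogen; it shows that the ring chlorines go with the lower number, and compound 3 carries none. Nothing measured speaks to the methyl on the amine nitrogen. Compound 3 is therefore expected to show a higher number, a 3.3-fold higher number from compound 2 to compound 3 (0.52 log units; beyond the scatter), with an estimated 8000 nM in this assay and a range from 2500 nM to 25000 nM.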

Compound 3, concentration for 50% growth inhibition: 16000 nM
Compound 3: the middle estimate sits 2.0-fold (0.30 log units) below what was measured; the range from low to high includes it.
By their numbers in this assay, from the lowest: compound 2; then compounds 1 and 3 (each within the scatter of the next).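

In this assay, replacing (3,4-dichlorobenzyl)amino with benzyl(methyl)amino at this chain carbon gives a 6.7-fold higher number from compound 2 to compound 3 (0.82 log units; beyond the scatter), a larger step than the chlorine change alone had suggested. Against the 2-chlorobenzyl compound, the same group gives a 1.8-fold higher number from compound 1 to compound 3 (0.26 log units; within the scatter), so at this position the two cannot be told apart. No evidence at hand explains either step.

The compounds shown leave open how this step divides between the ring chlorines and the methyl, as both change at once. A benzylamino group or a (3,4-dichlorobenzyl)(methyl)amino group would separate them.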